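The source may hold more compounds than are shown below. What is called first, only, known or untested is meant among the compounds shown, and "the series" means these compounds.

The series shares one core, seen in compound 1 `CCN(CC)S(=O)(=O)c1ccc(S(=O)(=O)N2CCC[C@@H](C(=O)N[C@@H]3CCN(C(=O)OC(C)(C)C)C3)C2)cc1`, compound 2 `CCOC(=O)[C@@H]1CCC[C@@H](S(=O)(=O)c2ccc(S(=O)(=O)N(CC)CC)cc2)C1` and compound 3 `CCN(CC)S(=O)(=O)c1ccc(S(=O)(=O)N2CCC[C@@H](C(=O)N(C)C(C)C)C2)cc1`. In a functional assay on MIA PaCa-2 cells (Homo sapiens) for inhibition, read by MTT assay, with a stated time of 3 days (a lower number here means a stronger inhibitor, a higher number a weaker inhibitor), compound 1 gives 500 nM, compound 2 gives 5000 nM and compound 3 gives 1400 nM. Compound 3 thus holds the second-highest of the three numbers: compound 1 is its nearest neighbour with a lower value, and compound 2 stands furthest with a higher one, both gaps beyond the scatter. Compound 4 `CCN(CC)S(=O)(=O)c1ccc(S(=O)(=O)N2CCC[C@@H](C(=O)NC3CN(C(=O)C4CC4)C3)C2)cc1` differs from compound 3 by (1-(cyclopropylcarbonyl)azetidin-3-yl)amino in place of isopropyl(methyl)amino on a carbonyl carbon, giving a secondary amide as in compound 1. Since compound 1 reaches 500 nM, the change is expected to lower the number. The expected step is a 2.3-fold lower number from compound 3 to compound 4 (0.37 log units; beyond the scatter). Compound 4 is estimated at 600 nM, between 200 nM and 2000 nM, in this assay.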

Compound 4, half-maximal inhibitory concentration: 3100 nM
For compound 4 the middle estimate is 5.2-fold (0.71 log units) below the measured one, outside the stated range (above it).
By their numbers in this assay, from the lowest: compound 1; then compound 3; then compounds 4 and 2 (each within the scatter of the next).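

In this assay a secondary amide on this carbonyl carbon does not by itself give a lower number: (1-(cyclopropylcarbonyl)azetidin-3-yl)amino in place of isopropyl(methyl)amino gives a 2.2-fold higher number from compound 3 to compound 4 (0.35 log units; beyond the scatter) here. The group on the amide-type nitrogen matters, as 1-(cyclopropylcarbonyl)azetidin-3-yl in place of 1-(tert-butoxycarbonyl)pyrrolidin-3-yl gives a 6.2-fold higher number from compound 1 to compound 4 (0.79 log units; beyond the scatter) in this series. No available evidence accounts for either step. Still open, going by these compounds, is whether the ring or its acyl group carries the second step, a question that 1-(cyclopropylcarbonyl)pyrrolidin-3-yl or 1-(tert-butoxycarbonyl)azetidin-3-yl on that nitrogen would address.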